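Ester-to-acid exchange on a cyclic peptide side chain

The compounds below may be only part of what the source reports. "The series", "measured", "known", "first", "only" and "open" are said of these compounds alone.

Working notes on the series. In a functional assay on P388 cells (Mus musculus) for cytotoxicity (a higher number here means a weaker inhibitor, a lower number a stronger inhibitor), compound 2 `COC(=O)C[C@@H]1NC(=O)[C@@H](C)NC(=O)[C@@H]2Cc3ccc(OC)c(c3)Oc3ccc(cc3)C[C@@H](C(=O)N2C)N(C)C(=O)[C@H](C)NC(=O)[C@H](Cc2ccc(OC)cc2)N(C)C1=O` gives 41.7 nM, the second highest of three numbers. Nearest is compound 3 `COc1ccc(C[C@H]2C(=O)N[C@@H](C)C(=O)N(C)[C@H]3Cc4ccc(cc4)Oc4cc(ccc4OC)C[C@@H](C(=O)N[C@H](C)C(=O)N[C@@H](CCCN=[N+]=[N-])C(=O)N2C)N(C)C3=O)cc1` with 35.5 nM; furthest is compound 1 `COC(=O)CC[C@@H]1NC(=O)[C@@H](C)NC(=O)[C@@H]2Cc3ccc(OC)c(c3)Oc3ccc(cc3)C[C@@H](C(=O)N2C)N(C)C(=O)[C@H](C)NC(=O)[C@H](Cc2ccc(OC)cc2)N(C)C1=O` with 58.9 nM; both gaps lie within the scatter. Compound 4 `COc1ccc(C[C@H]2C(=O)N[C@@H](C)C(=O)N(C)[C@H]3Cc4ccc(cc4)Oc4cc(ccc4OC)C[C@@H](C(=O)N[C@H](C)C(=O)N[C@@H](CC(=O)O)C(=O)N2C)N(C)C3=O)cc1` differs from compound 2 by hydrogen in place of methyl on an oxygen next to a carbonyl group.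

Measured steps that touch the same side chain: a 1.4-fold lower number from compound 1 to compound 2 (0.15 log units; within the scatter); a 1.2-fold lower number from compound 2 to compound 3 (0.07 log units; within the scatter); a 1.7-fold lower number from compound 1 to compound 3 (0.22 log units; within the scatter). All three sit within the scatter. None of them replaces the methyl on the ester oxygen, so the expectation rests only on the observation that each exchange made on this side chain has stayed within the scatter.

For the step to compound 4 the expected change is a 1.3-fold higher number from compound 2 to compound 4 (0.12 log units; within the scatter). Compound 4 is therefore estimated at 55 nM, with a range of 20 nM to 160 nM.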

Compound 4, half-maximal inhibitory concentration: 1200 nM
Estimate against measurement, compound 4: 22-fold (1.34 log units) below, and the stated range ends below it.
By their numbers in this assay, from the lowest: compounds 3, 2 and 1 (each within the scatter of the next); then compound 4.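

Among the compounds shown here, replacing the methyl on the ester oxygen with hydrogen is the first exchange on this side chain to move the number beyond the scatter in this assay, with a 29-fold higher number from compound 2 to compound 4 (1.46 log units; beyond the scatter). The carboxy compound stands equally clear of the other two, with a 34-fold higher number from compound 3 to compound 4 (1.53 log units; beyond the scatter) and a 20-fold higher number from compound 1 to compound 4 (1.31 log units; beyond the scatter), so this position does not accept every exchange. Nothing shown bears on the reason for this step.

Still open, going by these compounds, is whether a carboxylic acid on a longer chain would behave the same way. Also open, on these data alone, is whether an amine or primary amide at this position would stay with the esters and the azide.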